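Pyridin-3-yl for 2-aminophenyl on a dimethylated core

The compounds below may be only part of what the source reports. "The series", "measured", "known", "first", "only" and "open" are said of these compounds alone.

The set rests on three measured hydrazones and one awaiting measurement. Compound 1 `Nc1ccccc1C(=O)N/N=C/C1=C(Cl)c2ccccc2CCC1` carries a 2-aminophenyl on its carbonyl carbon; in a functional assay (MiaPaCa cells, Homo sapiens) for inhibition, read by sulforhodamine B assay, with a stated time of 48 h (on this read-out higher numbers stand for weaker inhibition of growth and lower numbers for stronger inhibition of growth), compound 1 gives 65100 nM. Compound 2 `O=C(N/N=C/C1=C(Cl)c2ccccc2CCC1)c1cccnc1` differs from it in one place, (pyridin-3-yl in place of 2-aminophenyl on a carbonyl carbon), and in this assay compound 2 gives 11700 nM. That single exchange produced a 5.6-fold lower number from compound 1 to compound 2 (0.75 log units; beyond the scatter).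

Compound 3 `Cc1cc2c(cc1C)C(Cl)=C(/C=N/NC(=O)c1ccccc1N)CCC2` keeps the 2-aminophenyl but sits on a different core; how the two cores differ is not broken down here. In this assay compound 3 gives 810 nM, the lowest of the three numbers, and its distance to compound 2 and to compound 1 is in each case beyond the usual scatter.

Compound 4 `Cc1cc2c(cc1C)C(Cl)=C(/C=N/NC(=O)c1cccnc1)CCC2` is not yet measured. It stands to compound 3 as compound 2 stands to compound 1: pyridin-3-yl in place of 2-aminophenyl on a carbonyl carbon. The place of the change is described in the same words for both pairs, so it is the same change made on a second core. Among the measured compounds shown here, the only measured instance of this change is the step from compound 1 to compound 2, a 5.6-fold lower number from compound 1 to compound 2 (0.75 log units; beyond the scatter), and on that single observation the expectation for compound 4 rests. Compound 4 is therefore expected to show a step of about a 4.1-fold lower number from compound 3 to compound 4 (0.61 log units; beyond the scatter) in this assay, a somewhat smaller shift than the earlier one, because the earlier step of a 5.6-fold lower number from compound 1 to compound 2 (0.75 log units; beyond the scatter) was seen on a different core and need not carry over in full. On this basis compound 4 is estimated at 200 nM, with a likely range from 70 nM to 600 nM.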

Compound 4, concentration for 50% growth inhibition: 1600 nM
Compound 4: middle estimate off by 8.0-fold (0.90 log units), on the low side; measured number outside the range, above it.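

In this assay, putting pyridin-3-yl in place of 2-aminophenyl on the core of compound 3 gives a 2.0-fold higher number from compound 3 to compound 4 (0.30 log units; within the scatter), so on this core the step does not stand out from repeated measurement. Set beside the first instance, the same change did not carry over from one core to the other: the same change on two cores in this assay, a 5.6-fold lower number (0.75 log units; beyond the scatter) from compound 1 to compound 2 and a 2.0-fold higher number (0.30 log units; within the scatter) from compound 3 to compound 4, 11-fold (1.04 log units) apart, beyond the scatter of two such steps. Among the compounds shown here, this shows that the step seen on the core of compound 1 cannot be moved as a fixed amount to the core of compound 3, but with only one pair on each core it does not show which difference between the cores goes with the gap, nor how the change would behave on any further core.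

The compounds shown leave open whether the two groups would part as far or as little on a core carrying methoxy groups in place of the methyl groups of compound 3. They also leave open whether another group on the carbonyl carbon, such as a cyclohexyl ring or a phenyl ring bearing a carboxylic acid, would give steps that agree across the two cores.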